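Moving the methoxy group on the amide-bearing phenyl ring

The source may hold more compounds than are shown below. What is called first, only, known or untested is meant among the compounds shown, and "the series" means these compounds.

Measured so far in an ADME assay on HUVEC cells (Homo sapiens) for cytotoxicity, read by MTT assay, with a stated time of 72 h; a lower number here means a stronger inhibitor, a higher number a weaker inhibitor:
compound 1, `O=C(CCC(=O)OCCCCCCSc1ccc([N+](=O)[O-])c2nonc12)Nc1ccccc1`: 2490 nM
compound 2, `COc1ccccc1NC(=O)CCC(=O)OCCCCCCSc1ccc([N+](=O)[O-])c2nonc12`: 1610 nM
compound 3, `Cc1ccc(NC(=O)CCC(=O)OCCCCCCSc2ccc([N+](=O)[O-])c3nonc23)cc1`: 2340 nM

Compound 2 stands at 1610 nM in this assay, and the numbers of compound 1 and compound 3 both lie within the scatter of it, so none of the three is set apart from the others.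

Compound 4, `COc1ccc(NC(=O)CCC(=O)OCCCCCCSc2ccc([N+](=O)[O-])c3nonc23)cc1`, has not yet been measured. It differs from compound 2 in one place: 4-methoxyphenyl in place of 2-methoxyphenyl on an amide-type nitrogen. The measured steps that touch the same phenyl ring are a 1.5-fold lower number from compound 1 to compound 2 (0.19 log units; within the scatter), a 1.1-fold lower number from compound 1 to compound 3 (0.03 log units; within the scatter) and a 1.5-fold higher number from compound 2 to compound 3 (0.16 log units; within the scatter). Each of them lies within the scatter, so changes of substituent and of substituent placement on this ring have so far left the number where it was.

Compound 4 is therefore expected to show no step beyond the scatter, an estimated 1.2-fold higher number from compound 2 to compound 4 (0.09 log units; within the scatter). The estimate for compound 4 is 2000 nM, with a range from 1000 nM to 4000 nM.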

Compound 4, half-maximal inhibitory concentration: 1590 nM
Compound 4: the middle estimate sits 1.3-fold (0.10 log units) above what was measured; the range from low to high includes it.
By their numbers in this assay, from the lowest: compounds 4, 2, 3 and 1 (each within the scatter of the next).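

In this assay, for the compounds shown here, this assay the methoxy group is the same in compound 2 and compound 4, so its placement is tested alone for the first time, and the 4-methoxyphenyl group in place of the 2-methoxyphenyl group leaves the number where it was (a 1.0-fold lower number from compound 2 to compound 4 (0.01 log units; within the scatter)). Methoxy in place of methyl (a 1.5-fold lower number from compound 3 to compound 4 (0.17 log units; within the scatter)) and methoxy in place of hydrogen (a 1.6-fold lower number from compound 1 to compound 4 (0.19 log units; within the scatter)) also stay within the scatter, so the four phenyl groups shown on the amide-type nitrogen cannot be told apart here. No measurement at hand offers an explanation for this flat result.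

The compounds shown leave open whether an amine or a carboxylic acid on this phenyl ring would move the number beyond the scatter. They also leave open whether a longer chain in place of the one shared by all four compounds would do so.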